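Aryl pyrazole diazepanes: meta methoxy analogue of the fluoro compound

The source may hold more compounds than are shown below. What is called first, only, known or untested is meant among the compounds shown, and "the series" means these compounds.

Compound 1 `Cc1cccc(-c2n[nH]cc2N2CCCNCC2)c1` gives > 10000 nM in an assay on isolated protein for binding affinity to 5-hydroxytryptamine receptor 1E (Homo sapiens) (a higher number here means a weaker inhibitor, a lower number a stronger inhibitor), a limit of the assay rather than a number.
Compound 2 `Fc1cccc(-c2n[nH]cc2N2CCCNCC2)c1` gives > 10000 nM in this assay, again a limit.
Compound 3 `COc1ccccc1-c1n[nH]cc1N1CCCNCC1` gives > 10000 nM in this assay, also a limit.

Compound 2 thus stands at the limit of this assay, with nothing measurable below it, as the limit of > 10000 nM in this assay, at which 3 of the 3 values shown sit, shows. Among the compounds with values here, the only step between measured compounds, a step that the two limits leave unreadable from compound 1 to compound 2, cannot be read in size or direction because the limit of > 10000 nM in this assay, at which 3 of the 3 values shown sit, leaves both ends undetermined. Compound 4 `COc1cccc(-c2n[nH]cc2N2CCCNCC2)c1` differs from compound 2 by methoxy in place of fluoro on an aromatic carbon. Within the data shown here, no measured step bears on this change, and compound 3 carries the same group elsewhere at the same limit. The expected step that the limit leaves unreadable from compound 2 to compound 4 is therefore none beyond the scatter, with compound 4 most likely again at the limit. Compound 4 is estimated at 15000 nM, between 4000 nM and 60000 nM, in this assay.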

Compound 4, inhibition constant: > 10000 nM
Compound 4: a limit, no number; the forecaster's own chance of this, stated with the estimate: 85%; the middle value is on the limit's open side.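

No step from compound 1 or compound 2 to compound 4 can be read in this assay, since each end is a limit of the assay: the limit of > 10000 nM in this assay, at which 4 of the 4 values shown sit.

The compounds shown leave open whether any change to the shared core gives a measurable value in this assay.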